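This account rests on a few compounds, and the source may have more. Where it says the series, first, only, none or still open, it means among the compounds named here.

Measured in an ADME assay on HaCaT cells (Homo sapiens) for cytotoxicity, read by MTT assay, with a stated time of 72 h; a lower number here means a stronger inhibitor, a higher number a weaker inhibitor:

compound 1 `COc1ccc(Nc2nnnn2-c2cccc(Br)c2)cc1`: 107000 nM
compound 2 `COc1ccc(-n2nnnc2Nc2cccc(Br)c2)cc1`: 138000 nM
compound 3 `COc1ccc(Nc2nnnn2-c2cccc(F)c2)cc1`: 101000 nM

Compound 1 and compound 2 have the same atoms joined differently; the difference between the two cores is not broken down here. All three numbers sit close together: compound 2 has the highest of the three, with compound 1 nearest at a gap within the scatter and compound 3 furthest, also within the scatter. No order among the three can be read from this.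

Among the measured compounds shown here, the only single-point step available is fluoro in place of bromo on an aromatic carbon, which gave a 1.1-fold lower number from compound 1 to compound 3 (0.03 log units; within the scatter).

Compound 4 `COc1ccc(-n2nnnc2Nc2cccc(F)c2)cc1` has not yet been run in this assay. It differs from compound 2 by fluoro in place of bromo on an aromatic carbon. The place described is the same word for word as in the step from compound 1 to compound 3, so this is taken as the same change on the other core.

For the measured compounds named here, the expected step for compound 4 is a 1.1-fold lower number from compound 2 to compound 4 (0.04 log units; within the scatter), set beside the earlier step, because a 1.1-fold lower number from compound 1 to compound 3 (0.03 log units; within the scatter) stayed within the scatter and nothing among the measured compounds points to a different outcome on the core of compound 2. In this assay compound 4 is therefore expected to give about 125000 nM. For compound 4 the expected range runs from 70000 nM to 220000 nM.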

Compound 4, half-maximal inhibitory concentration: 127000 nM
Estimate against measurement, compound 4: 1.0-fold (0.01 log units) below, within the range that was stated.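

In this assay fluoro in place of bromo on an aromatic carbon gives a 1.1-fold lower number from compound 2 to compound 4 (0.04 log units; within the scatter), so on this core too the swap stays within the scatter. Set beside the same change on the core of compound 1, the two steps do not differ: the same change on two cores in this assay, a 1.1-fold lower number (0.03 log units; within the scatter) from compound 1 to compound 3 and a 1.1-fold lower number (0.04 log units; within the scatter) from compound 2 to compound 4, 1.0-fold (0.01 log units) apart, within the scatter of two such steps. Among the compounds shown here, this shows that 3-bromophenyl to 3-fluorophenyl carries from one core to the other in the limited sense that neither core gives a step beyond the scatter, but it is agreement between two steps too small to read, so it does not show that a change of real size would carry across in the same way, and it rests on only two cores and one pair of groups at one place.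

The compounds shown leave open whether a different group at this place, such as an amine, a nitrile or a carboxylic acid, would give a step beyond the scatter, and whether such a step would then be the same on both cores. They also leave open what a group other than methoxy on the other aromatic ring, such as a longer alkoxy chain, would do to the number in this assay on either core.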